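Swapping a carboxyphenyl for a methoxyphenyl on a triazole sugar

This account rests on a few compounds, and the source may have more. Where it says the series, first, only, none or still open, it means among the compounds named here.

This set of sugar-linked triazoles is compared in a physicochemical assay for lipophilicity, read by LC-MS, using the shake flask method, in phosphate buffer, measured as octanol-water partition, with a stated time of 2 h, at pH 7.4; on this read-out higher numbers stand for higher lipophilicity and lower numbers for lower lipophilicity. On these data alone, compound 1 `O=C(O)c1cccc(-n2cc(CO[C@H]3O[C@H](CO)[C@@H](O)[C@H](O)[C@@H]3O)nn2)c1` gives "not determined" (no result reported) in this assay, so its own position is unknown. Compound 4 `COc1ccc(-n2cc(CO[C@H]3O[C@H](CO)[C@@H](O)[C@H](O)[C@@H]3O)nn2)cc1` differs from it by 4-methoxyphenyl in place of 3-carboxyphenyl on an aromatic nitrogen. The nearest guide is the pair compound 2 `COc1ccc(Cn2cc(CO[C@H]3O[C@H](CO)[C@@H](O)[C@H](O)[C@@H]3O)nn2)cc1` and compound 3 `OC[C@H]1O[C@H](OCc2cn(-c3cccc(F)c3)nn2)[C@@H](O)[C@@H](O)[C@@H]1O`: in this assay compound 2 gives -0.4, while compound 3 gives 0.18, a shift of a number 0.58 log units higher from compound 2 to compound 3 (beyond the scatter). Compound 4 carries a 4-methoxyphenyl directly on the ring nitrogen, as compound 3 carries its 3-fluorophenyl, so a value near that of compound 3, and above that of compound 2, seems the most plausible expectation. For compound 4 the estimate is 0.05, expected to lie between -0.45 and 0.55.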

Compound 4, distribution coefficient: -0.05
Estimate against measurement, compound 4: 0.10 log units above; the measured number falls inside the stated range.
By their numbers in this assay, from the lowest: compound 2; then compounds 4 and 3 (each within the scatter of the next).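

In this assay, 4-methoxyphenyl in place of 4-methoxybenzyl on the aromatic nitrogen gives a number 0.35 log units higher from compound 2 to compound 4 (beyond the scatter) and keeps the methoxy group, so this step is cleaner than the earlier one, where the fluorine and methoxy groups also differed. The swap of 3-fluorophenyl for 4-methoxyphenyl gives a number 0.23 log units lower from compound 3 to compound 4 (within the scatter), so these two groups cannot be told apart on this read-out. No supporting data explain either step.

Compound 1 gives "not determined" (no result reported), so the 3-carboxyphenyl group cannot be placed against the others. On these data alone, how an amine or a longer chain would behave on this nitrogen remains open.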